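Lengthening the nitrogen substituent from methyl to ethyl

The source may hold more compounds than are shown below. What is called first, only, known or untested is meant among the compounds shown, and "the series" means these compounds.

In a functional assay on NCI-H460 cells (Homo sapiens) for inhibition, with a stated time of 72 h (a lower number here means a stronger inhibitor, a higher number a weaker inhibitor), compound 1 (`COc1cc(C(=O)c2ccc3[nH]ccc3c2)cc(OC)c1OC`) gives 112 nM and compound 2 (`COc1cc(C(=O)c2ccc3c(ccn3C)c2)cc(OC)c1OC`) gives 14.1 nM, the lower of the two numbers. Compound 3 (`CCn1ccc2cc(C(=O)c3cc(OC)c(OC)c(OC)c3)ccc21`) differs from compound 2 by methyl in place of hydrogen on a saturated chain carbon bound to an aromatic nitrogen, which is methyl in place of hydrogen on a saturated chain carbon bound to an aromatic nitrogen. Among the compounds with values here, the only measured step is a 7.9-fold lower number from compound 1 to compound 2 (0.90 log units; beyond the scatter). It replaced hydrogen on the aromatic nitrogen itself, so it bears on this change only indirectly, and the data do not cover a longer chain. A small rise, close to the scatter, is expected, estimated as a 1.8-fold higher number from compound 2 to compound 3 (0.25 log units; within the scatter). Compound 3 is expected at 25 nM, within an estimated range of 8 nM to 80 nM.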

Compound 3, half-maximal inhibitory concentration: 38 nM
Estimate against measurement, compound 3: 1.5-fold (0.18 log units) below, and the stated range covers the measured number.
By their numbers in this assay, from the lowest: compound 2; then compound 3; then compound 1.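

In this assay, going from methyl to ethyl on the nitrogen gives back part of the earlier gain (a 2.7-fold higher number from compound 2 to compound 3 (0.43 log units; beyond the scatter)). Ethyl still keeps an advantage over the unsubstituted nitrogen (a 2.9-fold lower number from compound 1 to compound 3 (0.47 log units; beyond the scatter)), so of the three, methyl gives the lowest number and the position accepts ethyl without a full return to the hydrogen level. Nothing measured here explains this order. On these data alone, whether the number keeps rising with a longer chain such as propyl remains open. So does the effect of a branched group such as isopropyl, or of a hydroxyethyl chain, at this nitrogen.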